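Carbonyl substituent variation on a shared piperidine-bearing core

The source may hold more compounds than are shown below. What is called first, only, known or untested is meant among the compounds shown, and "the series" means these compounds.

Measured compounds:
compound 1 `Cc1nc(S(C)(=O)=O)ccc1Oc1ncnc(OC2CCN(C(=O)O[C@@H](C)C(F)(F)F)CC2)c1F`, 9.86 nM
compound 2 `Cc1nc(S(C)(=O)=O)ccc1Oc1ncnc(OC2CCN(C(=O)OC3COC3)CC2)c1F`, 326 nM
compound 3 `Cc1nc(S(C)(=O)=O)ccc1Oc1ncnc(OC2CCN(C(=O)C(C)(F)F)CC2)c1F`, 37 nM

All three share one core and differ only at the carbonyl carbon on the ring nitrogen. In a functional assay on isolated protein for inhibition of Glucose-dependent insulinotropic receptor (Homo sapiens), read by HTRF and cAMP accumulation (on this read-out higher numbers stand for an effect only at larger amounts of compound and lower numbers for an effect already at smaller amounts), compound 1 gives 9.86 nM, compound 2 gives 326 nM and compound 3 gives 37 nM. Compound 3 thus stands second of the three: a 3.8-fold higher number from compound 1 to compound 3 (0.57 log units; beyond the scatter), while an 8.8-fold lower number from compound 2 to compound 3 (0.95 log units; beyond the scatter). The remaining step, a 33-fold higher number from compound 1 to compound 2 (1.52 log units; beyond the scatter), shows how widely this position swings.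

Compound 4 `Cc1nc(S(C)(=O)=O)ccc1Oc1ncnc(OC2CCN(C(=O)C3CCCC3)CC2)c1F` is not yet measured. The change is cyclopentyl in place of 1,1-difluoroethyl on a carbonyl carbon. No measured step exchanges one carbon-only group for another at this position; the steps shown all involve fluorinated or oxygen-bearing groups and span modest to large changes in both directions. Nothing shown points to a clear direction, so for compound 4 a step within or only slightly beyond the scatter is expected, a 1.2-fold lower number from compound 3 to compound 4 (0.09 log units; within the scatter). The estimate for compound 4 in this assay is 30 nM, with a range from 8 nM to 110 nM.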

Compound 4, half-maximal effective concentration: 72.8 nM
The estimate for compound 4 lay 2.4-fold (0.39 log units) below the measured number; measured number inside the range.
By their numbers in this assay, from the lowest: compound 1; then compounds 3 and 4 (each within the scatter of the next); then compound 2.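

In this assay, the carbonyl carbon carries a ring of carbon only about as well as it carries 1,1-difluoroethyl, with a 2.0-fold higher number from compound 3 to compound 4 (0.29 log units; within the scatter) as the step, so the two fluorines of compound 3 are not needed to stay in this range. Cyclopentyl still leaves clear gaps to both carbamate-type groups, with a 4.5-fold lower number from compound 2 to compound 4 (0.65 log units; beyond the scatter) on one side and a 7.4-fold higher number from compound 1 to compound 4 (0.87 log units; beyond the scatter) on the other, and compound 4 therefore sits with compound 3 between them. No measurement here accounts for any of these differences.

What the compounds leave open is whether the 1-(trifluoromethyl)ethoxy result of compound 1 depends on the trifluoromethyl group or on the oxygen link, which a plain isopropoxy group would help to separate. As far as these compounds go, it is also open how a cyclohexyl ring or an amine on the same carbonyl carbon would read.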